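The source may report more compounds than this note shows. Statements on the series, on what has been measured and on what is new or still open speak of the compounds shown alone.

In a functional assay on the whole organism with Rattus norvegicus as the target (on this read-out lower numbers stand for an effect already at smaller amounts and higher numbers for an effect only at larger amounts of compound), compound 1, `CCc1c(OC)nc2nc(-c3nc(C)cs3)cn2c1C`, gives only a limit of the assay, > 50 mg/kg. Compound 2, `CCOC(=O)c1csc(-c2cn3c(C)c(CC)c(OC)nc3n2)n1`, likewise gives in this assay only a limit, > 50 mg/kg. The measured step that the two limits leave unreadable from compound 1 to compound 2 therefore has no readable size. Both values sit at the same limit, (the limit of > 50 mg/kg in this assay, at which 2 of the 2 values shown sit), so compound 2 stands at that limit itself and nowhere more precise on the numbers at hand.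

Compound 3, `CCc1c(OC)nc2nc(-c3nc(C(F)(F)F)cs3)cn2c1C`, differs from compound 2 in one place: trifluoromethyl in place of ethoxycarbonyl on an aromatic carbon. Going by the values given here, the only measured step that bears on this change, a step that the two limits leave unreadable from compound 1 to compound 2, offers no size, and no other step in this assay is available; nothing in the data points to a step beyond the scatter in either direction. Compound 3 is expected to stand near 50 mg/kg, within a range from 15 mg/kg to 150 mg/kg, and would most likely be reported again as a limit rather than a number. The step that this estimate means, a number no higher from compound 2 to compound 3 (the limit leaves the size open), is expected to be no larger than the scatter.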

Compound 3, minimum effective dose: > 50 mg/kg
Compound 3 was reported as a limit (the forecaster's own chance of this, stated with the estimate: 70%); the middle value sits exactly at the limit.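

No step among compound 1, compound 2 and compound 3 can be read in this assay, since each of these compounds gives only a limit there: the limit of > 50 mg/kg in this assay, at which 3 of the 3 values shown sit.

The compounds shown leave open whether methyl, ethoxycarbonyl or trifluoromethyl on this aromatic carbon makes any difference to the effect, and how the three compounds would compare on actual numbers.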